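Swapping the Piperazine Substituent on a Weak Cell-Growth Inhibitor

A few compounds are considered here, and "the series" means these few. Any claim that something is new, unique, unknown or untested is made for them only; others in the source may bear on it.

Three compounds share one core and differ only in the amine attached through a butynyl linker. In a functional assay on A549 cells (Homo sapiens) for inhibition, read by sulforhodamine B assay (on this read-out lower numbers stand for stronger inhibition and higher numbers for weaker inhibition), compound 1, `COC(=O)CC/C(C)=C/Cc1c(OC)c(C)c2c(c1OCC#CCN1CCN(c3ccc(C)cc3)CC1)C(=O)OC2`, gives > 50000 nM, which is a limit of the assay rather than a measured number. Compound 2, `COC(=O)CC/C(C)=C/Cc1c(OC)c(C)c2c(c1OCC#CCN1CCN(C(c3ccccc3)c3ccccc3)CC1)C(=O)OC2`, gives 32700 nM in this assay. Compound 3, `COC(=O)CC/C(C)=C/Cc1c(OC)c(C)c2c(c1OCC#CCN1CCCc3ccccc31)C(=O)OC2`, gives 18000 nM. Compound 1 thus stands apart from the other two, since (the limit of > 50000 nM in this assay, at which 1 of the 3 values shown sits), while compounds 2 and 3 both return numbers.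

Compound 4, `COC(=O)CC/C(C)=C/Cc1c(OC)c(C)c2c(c1OCC#CCN1CCN(Cc3ccc(Cl)cc3)CC1)C(=O)OC2`, has not yet been tested. It differs from compound 1 in one place: 4-chlorobenzyl in place of 4-methylphenyl on an amine nitrogen in a ring. For the measured compounds named here, no measured pair with a single change exists here, so the step is judged only from the spread of the three values. A modest gain toward the range of compounds 2 and 3 is expected, and the step of an at least 1.6-fold lower number from compound 1 to compound 4 (0.22 log units; that floor lies within the scatter) is the estimated size. Compound 4 is expected to give about 30000 nM in this assay, with a likely range from 10000 nM to 100000 nM.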

Compound 4, half-maximal inhibitory concentration: > 50000 nM
Compound 4 ended at the assay's limit; the forecaster's own chance of this, stated with the estimate: 30%; middle value at least 1.6-fold (0.22 log units) away from the limit.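

No step from compound 1 to compound 4 can be read, because both results are limits of the assay rather than numbers: the limit of > 50000 nM in this assay, at which 2 of the 4 values shown sit.

The compounds shown leave open whether 4-chlorobenzyl in place of 4-methylphenyl changes inhibition at all in this assay.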